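This account rests on a few compounds, and the source may have more. Where it says the series, first, only, none or still open, it means among the compounds named here.

Measured so far in a functional assay on NCI-H1975 cells (Homo sapiens) for inhibition, read by MTT assay, with a stated time of 72 h; on this read-out lower numbers stand for stronger inhibition and higher numbers for weaker inhibition:
compound 1 `O=C(CSc1nc(Nc2ccccc2)c2ccccc2n1)Nc1ccccc1Cl` gives 9610 nM
compound 2 `O=C(CSc1nc(Nc2ccccc2)c2ccccc2n1)Nc1cccc(Cl)c1` gives 8460 nM
compound 3 `CCc1cccc(NC(=O)CSc2nc(Nc3ccccc3)c3ccccc3n2)c1` gives 12000 nM

Compound 2 holds the lowest of the three numbers in this assay, yet the step of a 1.1-fold lower number from compound 1 to compound 2 (0.06 log units; within the scatter) and the step of a 1.4-fold higher number from compound 2 to compound 3 (0.15 log units; within the scatter) both sit within the scatter, so no order among the three can be claimed. Compound 4 `O=C(CSc1nc(Nc2ccccc2)c2ccccc2n1)Nc1ccc(F)c(Cl)c1` carries fluoro in place of hydrogen on an aromatic carbon. Among the measured compounds shown here, no measured step adds a fluoro group; the steps that do alter the amide-bearing ring, a 1.1-fold lower number from compound 1 to compound 2 (0.06 log units; within the scatter), a 1.2-fold higher number from compound 1 to compound 3 (0.10 log units; within the scatter) and a 1.4-fold higher number from compound 2 to compound 3 (0.15 log units; within the scatter), all stay within the scatter. On that basis no step beyond the scatter is expected, a 1.0-fold higher number from compound 2 to compound 4 (0.00 log units; within the scatter). Compound 4 is estimated at 8500 nM, in the range 4000 nM to 18000 nM.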

Compound 4, half-maximal inhibitory concentration: 9390 nM
Beside the measured number, compound 4's estimate is 1.1-fold (0.04 log units) below it, and the stated range covers the measured number.
By their numbers in this assay, from the lowest: compounds 2, 4, 1 and 3 (each within the scatter of the next).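

In this assay, fluoro on the aromatic carbon ortho to a chloro group and para to a large group gives a 1.1-fold higher number from compound 2 to compound 4 (0.05 log units; within the scatter), so this position takes a fluoro group with no step beyond the scatter. The 3-chloro-4-fluorophenyl group also stays within the scatter of its 3-ethylphenyl and 2-chlorophenyl counterparts, with a 1.3-fold lower number from compound 3 to compound 4 (0.11 log units; within the scatter) and a 1.0-fold lower number from compound 1 to compound 4 (0.01 log units; within the scatter). No evidence bearing on this result is available.

Still open, going by these compounds, is whether an amine or a carboxylic acid at this position moves the number beyond the scatter. Also open, on these data alone, is whether any change to the shared core does so.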